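Adding a Second Fluorine to a Urea TRPV1 Antagonist

The source may report more compounds than this note shows. Statements on the series, on what has been measured and on what is new or still open speak of the compounds shown alone.

Compound 1, `Cn1ncc2c(NC(=O)NCc3cc(C(F)(F)F)nn3-c3cccc(Cl)c3)cccc21`, gives 2.3 nM in an assay on CHO-K1 cells for antagonist activity at transient receptor potential cation channel subfamily V member 1 (Homo sapiens), read by FLIPR and calcium flux, with a stated time of 6 min; on this read-out lower numbers stand for stronger inhibition and higher numbers for weaker inhibition.
Compound 2, `CC(C)(C)c1cc(CNC(=O)Nc2cccc3[nH]ncc23)n(-c2cccc(F)c2)n1`, gives 1.3 nM in this assay.

Among the compounds with values here, compound 2 holds the lowest of the two numbers measured so far, but its nearest neighbour, compound 1, sits within the scatter of it, so the two cannot be ranked against each other.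

Compound 3, `CC(C)(C)c1cc(CNC(=O)Nc2cccc3[nH]ncc23)n(-c2ccc(F)c(F)c2)n1`, has not yet been measured. It differs from compound 2 in one place: fluoro in place of hydrogen on an aromatic carbon. Seen one bond further out, the change reads 3-fluorophenyl to 3,4-difluorophenyl, a single small atom added at the edge of the shared core.

Within the data shown here, no measured pair shows such a change, so there is no step to lean on. A single fluoro added to an aromatic ring is usually a modest adjustment. The step of a 1.2-fold higher number from compound 2 to compound 3 (0.09 log units; within the scatter) is therefore expected to be small, most likely none beyond the scatter. Compound 3 is expected to give 1.6 nM, with a range from 0.5 nM to 5 nM.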

Compound 3, inhibition constant: 0.5 nM
The estimate for compound 3 lay 3.2-fold (0.51 log units) above the measured number; low and high end bracket the measured number.
By their numbers in this assay, from the lowest: compound 3; then compounds 2 and 1 (each within the scatter of the next).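

In this assay, going from 3-fluorophenyl to 3,4-difluorophenyl gives a 2.6-fold lower number from compound 2 to compound 3 (0.41 log units; beyond the scatter) and so moves the number towards stronger inhibition. This is the first single-place change among these compounds, and it shows that the aromatic carbon ortho to a fluoro group and para to a large group is not indifferent to what it carries: one added fluorine atom at the edge of the shared core is enough to take the step beyond the scatter. Nothing measured here explains why the number moves.

From the compounds shown here alone, whether fluoro is special at this carbon, or whether a methoxy group or a nitrile there would give a similar step, remains open. Going by these compounds, it is also open whether the same change would have a similar effect on the core of compound 1.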